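The compounds below may be only part of what the source reports. "The series", "measured", "known", "first", "only" and "open" are said of these compounds alone.

Compound 1 `O/N=C(/Nc1cccc(F)c1)c1ccc2occc2c1`: 20000 nM
Compound 2 `COCc1cc2cc(/C(=N\O)Nc3cccc(F)c3)ccc2o1`: 6100 nM

Within the data shown here, in an assay on tissue (HeLa cells) for inhibition of Indoleamine 2,3-dioxygenase 1 (Homo sapiens), read by spectrophotometry (on this read-out higher numbers stand for weaker inhibition and lower numbers for stronger inhibition), compound 2 holds the lowest of the two numbers so far, with compound 1 the only neighbour, reached by a 3.3-fold lower number from compound 1 to compound 2 (0.52 log units; beyond the scatter). Compound 3 `O/N=C(/Nc1cccc(F)c1)c1ccc2oc(COCC3CC3)cc2c1` differs from compound 2 by cyclopropyl in place of hydrogen on a saturated chain carbon bound to an oxygen on a saturated carbon, so it extends the very group that was added in that earlier step. Among the measured compounds shown here, no measured step mirrors this extension; the only related step is the modest one from compound 1 to compound 2. On that basis the step to compound 3 is expected to be small, perhaps slightly downward. The estimated step is a 1.5-fold lower number from compound 2 to compound 3 (0.18 log units; within the scatter). Compound 3 is therefore expected to give about 4000 nM, between 1500 nM and 12000 nM.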

Compound 3, half-maximal inhibitory concentration: 8000 nM
Compound 3: the middle estimate sits 2.0-fold (0.30 log units) below what was measured; the measured number falls inside the stated range.
By their numbers in this assay, from the lowest: compounds 2 and 3 (each within the scatter of the next); then compound 1.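

In this assay, extending the methoxymethyl group to (cyclopropylmethoxy)methyl gives a 1.3-fold higher number from compound 2 to compound 3 (0.12 log units; within the scatter), so this position accepts the larger group without a measurable change. Relative to hydrogen on the aromatic carbon, the extended group still gives a 2.5-fold lower number from compound 1 to compound 3 (0.40 log units; beyond the scatter) and thus retains a modest advantage. No supporting evidence bears on why this is so. The compounds shown leave open whether an amine, a carboxylic acid or a longer chain at this position would move the number beyond the scatter. They also leave open whether a group without the ether oxygen would do the same.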